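Methoxy for methyl on the second aryl ring

This account rests on a few compounds, and the source may have more. Where it says the series, first, only, none or still open, it means among the compounds named here.

Compound 1 `CCC(=O)N1N=C(c2ccc(C)cc2)CC1c1ccc(C)cc1` and compound 2 `CCC(=O)N1N=C(c2ccc(C)cc2)CC1c1ccc(OC)cc1` share one core and differ only in one aryl substituent. In an assay on isolated protein for inhibition of Amine oxidase [flavin-containing] A (Bos taurus) (a lower number here means a stronger inhibitor, a higher number a weaker inhibitor), compound 1 gives 100000 nM, and in this assay compound 2 gives 74100 nM. The step of a 1.3-fold lower number from compound 1 to compound 2 (0.13 log units; within the scatter) is the only one recorded. Compound 2 therefore stands with the lower of the two numbers, yet its distance to compound 1 is within the scatter, so no order between the two can be read.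

Compound 3 `CCC(=O)N1N=C(c2ccc(OC)cc2)CC1c1ccc(OC)cc1` is not yet measured. It differs from compound 2 by methoxy in place of methyl on an aromatic carbon, which reads 4-methylphenyl to 4-methoxyphenyl at the second aryl ring. The same exchange on the other ring, a 1.3-fold lower number from compound 1 to compound 2 (0.13 log units; within the scatter), stayed within the scatter. On that basis the step of a 1.2-fold lower number from compound 2 to compound 3 (0.09 log units; within the scatter) is expected to be small, with no clear direction beyond the scatter. For compound 3 in this assay the estimate is 60000 nM, within 30000 nM to 120000 nM.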

Compound 3, half-maximal inhibitory concentration: 1170 nM
Beside the measured number, compound 3's estimate is 51-fold (1.71 log units) above it, and the stated range ends above it.
By their numbers in this assay, from the lowest: compound 3; then compounds 2 and 1 (each within the scatter of the next).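

In this assay 4-methoxyphenyl in place of 4-methylphenyl at this ring gives a 63-fold lower number from compound 2 to compound 3 (1.80 log units; beyond the scatter) while the same exchange on the other ring gave a 1.3-fold lower number from compound 1 to compound 2 (0.13 log units; within the scatter) and so produced no readable change. The exchange therefore cannot be treated as equivalent on the two rings of this series: its outcome depends on the ring that carries it, on the methoxy already present on the other ring, or on both. No measurement bearing on the reason for this large step is available.

These compounds do not separate those readings, since none pairs a methoxy at this ring with a methyl on the other. Also open, from the compounds shown here alone, is how a hydroxy group, an ethoxy group or an amine would read at this position.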